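Compound 1: 2-methoxyphenyl to 2-hydroxyphenyl

The source may hold more compounds than are shown below. What is called first, only, known or untested is meant among the compounds shown, and "the series" means these compounds.

Of the compounds shown here, three have values so far. In a functional assay on HOS cells (Homo sapiens) for inhibition, with a stated time of 72 h (a lower number here means a stronger inhibitor, a higher number a weaker inhibitor), compound 1 `COc1ccccc1-c1ccc(CNc2nc(NC3CCC(N)CC3)nc3c2ncn3C2CCCC2)cc1` gives 150 nM. Compound 2 `NC1CCC(Nc2nc(NCc3ccc(-c4ccccc4)nc3)c3ncn(C4CCCC4)c3n2)CC1` gives 206 nM, which lies within the scatter of the value for compound 1, so the two cannot be ranked. Compound 3 `CC(C)(O)CNc1nc(NCc2ccc(-c3ccco3)nc2)c2ncn(C3CCCC3)c2n1` gives 560 nM, and its distance from compound 1 lies beyond the scatter, on the higher side. Compound 1 therefore stands clear of compound 3 but not of compound 2.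

Compound 4 `NC1CCC(Nc2nc(NCc3ccc(-c4ccccc4O)cc3)c3ncn(C4CCCC4)c3n2)CC1` is still unmeasured. It departs from compound 1 in one place, where 2-methoxyphenyl becomes 2-hydroxyphenyl: hydrogen in place of methyl on an oxygen on an aromatic ring.

For the measured compounds named here, no two measured compounds differ in a single place, so the series gives no direct reading of this change. The only indirect hint is that compound 1 at 150 nM and compound 2 at 206 nM stay within the scatter although their structures differ at the aryl end. In this assay a small step is therefore expected, probably within the scatter, with a slight lean towards a higher number. The estimated change is a 1.3-fold higher number from compound 1 to compound 4 (0.12 log units; within the scatter). For compound 4 the expected value is 200 nM, with an estimated range of 70 nM to 600 nM.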

Compound 4, half-maximal inhibitory concentration: 1160 nM
Compound 4: the middle estimate sits 5.8-fold (0.76 log units) below what was measured; measured number outside the range, above it.
By their numbers in this assay, from the lowest: compounds 1 and 2 (each within the scatter of the next); then compound 3; then compound 4.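

In this assay, for the compounds shown here, hydrogen in place of methyl on the oxygen on the aromatic ring gives a 7.7-fold higher number from compound 1 to compound 4 (0.89 log units; beyond the scatter), the first step that isolates a single change, and it lies beyond the scatter. Only one heavy atom, a carbon, leaves, with no ring and no net charge involved, so the earlier closeness of values between compounds with different aryl ends gives no licence to treat this methoxy group as freely replaceable. Nothing available here accounts for the size of this step, and the result stands as an observation without an assigned reason.

Open, from the compounds shown here alone, is how other groups on this oxygen would read, for example ethyl in place of methyl, and how an amine or a fluorine would read in place of the methoxy group on the same ring. Also open, going by these compounds, is whether methoxy to hydroxy gives a step of similar size when the rest of the molecule differs from compound 1, as the aminocyclohexyl end would if exchanged for another amine or a longer chain.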